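This account rests on a few compounds, and the source may have more. Where it says the series, first, only, none or still open, it means among the compounds named here.

Values so far in a functional assay on the whole organism for antagonist activity, with Mus musculus as the target; a higher number here means that more compound is needed for the effect, a lower number that less compound is needed

Compound 1 `CC(=O)N(C)C(C)C#CCn1cncc1C` gives 80 mg/kg
Compound 2 `CC(=O)N(C)CC#CCn1cncc1C` gives > 100 mg/kg

For compound 2, > 100 mg/kg is a limit of the assay and not a number. Its exact standing in this assay is therefore unknown.

Compound 3 `Cc1cncn1CC#CCN(C)C(=O)N(C)C` differs from compound 2 at one place, (dimethylamino in place of methyl on a carbonyl carbon), with dimethylamino in place of methyl on a carbonyl carbon. Among the measured compounds shown here, the one measured step, an at least 1.2-fold higher number from compound 1 to compound 2 (0.09 log units; that floor lies within the scatter), concerns a saturated chain carbon instead, and its floor lies within the scatter. For the measured compounds named here, no measured step involves the carbonyl carbon, so the data offer no basis for expecting a shift in either direction. The estimate is thus a step that the limit leaves unreadable from compound 2 to compound 3, which is expected to stay within the scatter. For compound 3 the estimated value is 120 mg/kg, with an expected range from 50 mg/kg to 300 mg/kg.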

Compound 3, dose for half-maximal effect: > 100 mg/kg
Compound 3 was reported as a limit (the forecaster's own chance of this, stated with the estimate: 60%); the middle value is on the limit's open side.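

In this assay, among the compounds shown here, compound 2 and compound 3 are both reported as limits and not as numbers, so no step between them can be read: the limit of > 100 mg/kg in this assay, at which 2 of the 3 values shown sit. On these data alone, whether dimethylamino in place of methyl on a carbonyl carbon changes the dose needed, and in which direction, stays open.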